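A Bicyclic Amine in Place of Cyclohexyl

The source may hold more compounds than are shown below. What is called first, only, known or untested is meant among the compounds shown, and "the series" means these compounds.

Of the compounds shown here, three with a shared core have been tested in a functional assay on the whole organism (blood) with Rattus norvegicus as the target, with stated times of 24 h and 1 h, at a dose of 5 mg/kg by the intraperitoneal route; a lower number here means a weaker effect, a higher number a stronger effect of the compound at the dose given. For the measured compounds named here, compound 1 `COc1ccc(Cl)cc1C(=O)NCCC1CCN(S(=O)(=O)NC(=O)NC[C@@H]2C[C@@H]3C=C[C@@H]2C3)CC1` gives 37%, and compound 2 `Cc1ncsc1C(=O)NCCC1CCN(S(=O)(=O)NC(=O)NC[C@@H]2C[C@@H]3C=C[C@@H]2C3)CC1` gives 11%; the one single-point step between measured compounds is a number 26 percentage points lower from compound 1 to compound 2 (beyond the scatter). Compound 3 `Cc1ncccc1C(=O)NCCC1CCN(S(=O)(=O)NC(=O)NC2CCCCC2)CC1` gives 16%, the second highest of the three numbers: it lies within the scatter of compound 2 and sits beyond the scatter below compound 1.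

Compound 4 `Cc1ncccc1C(=O)NCCC1CCN(S(=O)(=O)NC(=O)NC[C@@H]2C[C@@H]3C=C[C@@H]2C3)CC1` has not yet been measured. It differs from compound 3 in one place: a group of 8 heavy atoms (8 carbon; 2 five-membered non-aromatic rings of carbon only) in place of a group of 6 heavy atoms (6 carbon; one six-membered non-aromatic ring of carbon only), on an amide-type nitrogen. The group that enters is the same one carried by compound 1 and compound 2. Going by the values given here, the single measured step concerns a change on a carbonyl carbon and so does not touch the amide-type nitrogen changed here. Compound 2 and compound 3, which differ in two places, show values within the scatter of each other, which gives no direction either. With nothing to point up or down, the step of a number 2 percentage points higher from compound 3 to compound 4 (within the scatter) is expected to stay within the scatter. Compound 4 is therefore estimated to give about 18% in this assay, most likely between 5% and 34%.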

Compound 4, a percentage reported as activity, at one dose (the size of the read-out at that dose, not a potency): 16%
Beside the measured number, compound 4's estimate is 2 percentage points above it; low and high end bracket the measured number.
By their numbers in this assay, from the lowest: compounds 2, 3 and 4 (each within the scatter of the next); then compound 1.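

In this assay, the first direct test at the amide-type nitrogen gives no change at the digits printed from compound 3 to compound 4 (within the scatter), so with 2-methylpyridin-3-yl on the carbonyl carbon, the entering group of 8 carbons in two five-membered rings cannot be told apart from cyclohexyl at this dose. Compound 4 also adds two steps at the carbonyl carbon: a number 5 percentage points higher from compound 2 to compound 4 (within the scatter) shows that 2-methylpyridin-3-yl and 4-methyl-1,3-thiazol-5-yl cannot be told apart, whereas a number 21 percentage points lower from compound 1 to compound 4 (beyond the scatter) shows a real loss when 2-methylpyridin-3-yl replaces 5-chloro-2-methoxyphenyl, so with this nitrogen group the change at the carbonyl carbon moves the number more than the change at the nitrogen did. No measurement is available to explain either result.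

On these data alone, whether cyclohexyl and the entering group would also match each other with 5-chloro-2-methoxyphenyl on the carbonyl carbon remains open. Also open, as far as these compounds go, is what a carboxylic acid or a longer carbon chain on the amide-type nitrogen would do to the read-out.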